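Ester-to-ether exchange on the side-chain oxygen of compound 1

The compounds below may be only part of what the source reports. "The series", "measured", "known", "first", "only" and "open" are said of these compounds alone.

Measured so far in a functional assay on HeLa cells (Homo sapiens) for cytotoxicity, read by MTT assay; a lower number here means a stronger inhibitor, a higher number a weaker inhibitor:
compound 1 `CC(C)=CC[C@@H](OC(=O)CCO)C1=CC(=O)c2c(O)ccc(O)c2C1=O` gives 67600 nM
compound 2 `CC(=O)OC(C)CO[C@H](CC=C(C)C)C1=CC(=O)c2c(O)ccc(O)c2C1=O` gives 40100 nM
compound 3 `CC[C@@](C)(O)CC(=O)O[C@H](CC=C(C)C)C1=CC(=O)c2c(O)ccc(O)c2C1=O` gives 17900 nM

Compound 1 has the highest of the three numbers in this assay. Its nearest neighbour is compound 2, with a 1.7-fold lower number from compound 1 to compound 2 (0.23 log units; within the scatter), and the furthest is compound 3, with a 3.8-fold lower number from compound 1 to compound 3 (0.58 log units; beyond the scatter). Between the other two the step is a 2.2-fold lower number from compound 2 to compound 3 (0.35 log units; beyond the scatter).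

Compound 4 `CC(C)=CC[C@@H](OCCO)C1=CC(=O)c2c(O)ccc(O)c2C1=O` has not been measured. It differs from compound 1 in one place: 2-hydroxyethyl in place of (2-hydroxyethyl)carbonyl on an oxygen on a saturated carbon. The side-chain oxygen thus carries a 2-hydroxyethyl group instead of a (2-hydroxyethyl)carbonyl group, the hydroxyl at the chain end being kept.

Among the measured compounds shown here, the step that bears most directly on this is the one from compound 1 to compound 2, where the (2-hydroxyethyl)carbonyl was likewise exchanged for a group without the carbonyl on that oxygen, and the step stayed within the scatter. The step from compound 2 to compound 3 went the other way, from a group without a carbonyl to one with a carbonyl, and was modest. Taken together these suggest that the presence or absence of the carbonyl on this oxygen moves the number little. For compound 4 the expected step is therefore a 1.2-fold lower number from compound 1 to compound 4 (0.09 log units; within the scatter), a change not clearly beyond the scatter. Compound 4 is estimated at 55000 nM, with a range from 25000 nM to 120000 nM.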

Compound 4, half-maximal inhibitory concentration: 18600 nM
Estimate against measurement, compound 4: 3.0-fold (0.47 log units) above, outside the stated range (below it).
By their numbers in this assay, from the lowest: compounds 3 and 4 (each within the scatter of the next); then compounds 2 and 1 (each within the scatter of the next).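

Among the compounds shown here, on an oxygen on a saturated carbon, the change from (2-hydroxyethyl)carbonyl to 2-hydroxyethyl is a real step in this assay, with a 3.6-fold lower number from compound 1 to compound 4 (0.56 log units; beyond the scatter), so the earlier compounds understated what this exchange can do. The presence or absence of the carbonyl does not by itself order the series: 2-hydroxyethyl gives a 2.2-fold lower number from compound 2 to compound 4 (0.33 log units; beyond the scatter), yet compound 2 also lacks the carbonyl, while the carbonyl-bearing group of compound 3 gives a 1.0-fold higher number from compound 3 to compound 4 (0.02 log units; within the scatter), leaving the two groups within the scatter of each other. The data offer no measured explanation for these steps.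

Going by these compounds, it remains open whether the hydroxyl of the 2-hydroxyethyl group contributes to the number of compound 4, which a plain ethyl group on this oxygen would test. On these data alone, it is equally open whether 2-aminoethyl, carboxymethyl or the longer 3-hydroxypropyl on this oxygen would stay within the scatter of compound 4 or move away from it, and so how much room this position allows.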